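Spiro series: aryl swap on the triazole nitrogen

A few compounds are considered here, and "the series" means these few. Any claim that something is new, unique, unknown or untested is made for them only; others in the source may bear on it.

Compound 3 `CCOc1ccc(-n2nncc2CN2C(=O)C3(C(C#N)=C(N)Oc4c3c3nc5ccccc5nc3c3ccccc43)c3ccccc32)cc1` is one of three measured members of the series; the other two are compound 1 `N#CC1=C(N)Oc2c(c3nc4ccccc4nc3c3ccccc23)C12C(=O)N(Cc1cnnn1-c1cccc(Cl)c1)c1ccccc12` and compound 2 `COc1ccccc1-n1nncc1CN1C(=O)C2(C(C#N)=C(N)Oc3c2c2nc4ccccc4nc2c2ccccc32)c2ccccc21`. In a functional assay on HCT-116 cells (Homo sapiens) for antiproliferative activity, read by MTT assay, with a stated time of 48 h (on this read-out lower numbers stand for stronger inhibition and higher numbers for weaker inhibition), compound 3 gives > 50000 nM, which is a limit of the assay and not a number. Compound 1 likewise gives > 50000 nM, a limit. Compound 2 gives > 50000 nM, again a limit. Compound 3 therefore stands at the limit together with every other measured value, as summarised by the limit of > 50000 nM in this assay, at which 3 of the 3 values shown sit.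

Compound 4 `N#CC1=C(N)Oc2c(c3nc4ccccc4nc3c3ccccc23)C12C(=O)N(Cc1cnnn1-c1ccc(F)c(Cl)c1)c1ccccc12` is not yet measured. It differs from compound 3 in one place: 3-chloro-4-fluorophenyl in place of 4-ethoxyphenyl on an aromatic nitrogen. Three measured steps change the same aryl group on the aromatic nitrogen: a step that the two limits leave unreadable from compound 1 to compound 2, a step that the two limits leave unreadable from compound 1 to compound 3 and a step that the two limits leave unreadable from compound 2 to compound 3. None of them has a readable size, since all three values sit at the limit; they show only that none of the three aryl groups brings the series into the measurable range. Compound 1 carries 3-chlorophenyl, the nearest relative of the 3-chloro-4-fluorophenyl entering in compound 4, and it also sits at the limit. Compound 4 is therefore expected to remain at or beyond the limit, with a step that the limit leaves unreadable from compound 3 to compound 4 expected to be no readable step. The estimate for compound 4 in this assay is 80000 nM, in the range 20000 nM to 300000 nM.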

Compound 4, half-maximal inhibitory concentration: > 50000 nM
Compound 4: only a limit was reported; the forecaster's own chance of this, stated with the estimate: 85%; the middle value is on the limit's open side.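

Compound 4 adds no readable step against compound 1, compound 2 or compound 3 in this assay; all these values are limits of the assay and not numbers: the limit of > 50000 nM in this assay, at which 4 of the 4 values shown sit.

The compounds shown leave open how far past the limit each one lies, and whether any aryl group on this aromatic nitrogen brings the series into the measurable range.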